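The source may hold more compounds than are shown below. What is called first, only, known or untested is meant among the compounds shown, and "the series" means these compounds.

Working notes on the series, followed in a functional assay on Raji cells (Homo sapiens) for cytotoxicity, with a stated time of 72 h; on this read-out lower numbers stand for an effect already at smaller amounts and higher numbers for an effect only at larger amounts of compound. Compound 1 `C=C[C@@](C)(/C=C/c1ccc(OC)cc1)CCC=C(C)C` gives only a limit of the assay in this assay, > 26000 nM. Compound 2 `CC(C)=CCC[C@](C)(/C=C/c1ccc(O)cc1)/C=C/c1cccc(Cl)c1` also gives only a limit of the assay in this assay, > 26000 nM. Within the data shown here, compound 1 therefore stands at the limit of > 26000 nM in this assay, at which 2 of the 2 values shown sit; no numbered value exists for it, and with no pair of measured compounds that differ in one place, no measured step in this assay can be sized.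

Compound 3 `C=C[C@@](C)(/C=C/c1ccc(Nc2ccc(Cl)c(F)c2)cc1)CCC=C(C)C` differs from compound 1 by (4-chloro-3-fluorophenyl)amino in place of methoxy on an aromatic carbon. Nothing measured in the series bears on this change. The step is expected to move toward an effect at smaller amounts, an at least 1.7-fold lower number from compound 1 to compound 3 (0.23 log units; that floor lies within the scatter), though the figure is uncertain and a limit may well be reported again. Compound 3 is estimated at 15000 nM in this assay, within a range from 3000 nM to 60000 nM.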

Compound 3, half-maximal effective concentration: > 26000 nM
Compound 3 was reported as a limit; the forecaster's own chance of this, stated with the estimate: 55%; middle value at least 1.7-fold (0.23 log units) from the limit.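

Among these compounds, compound 1 and compound 3 both give only a limit of the assay in this assay, so no step between them can be read: the limit of > 26000 nM in this assay, at which 3 of the 3 values shown sit.

The compounds shown leave open whether any member of the series reaches a numbered value, and how far (4-chloro-3-fluorophenyl)amino and methoxy differ on the shared core.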